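Swapping Chloro for Methoxy on a Melanoma Growth Inhibitor

The source may report more compounds than this note shows. Statements on the series, on what has been measured and on what is new or still open speak of the compounds shown alone.

Compound 1, `COc1cc2c(/C=C3/C(=O)Nc4ccc(Cl)cc43)c(Cl)n(Cc3cc(OC)c(OC)c(OC)c3)c2cc1C`, was tested in a functional assay on cells (Melanoma cell, Homo sapiens) for cytotoxicity, with a stated time of 48 h (a lower number here means a stronger inhibitor of growth, a higher number a weaker inhibitor of growth), where compound 1 gives 2290 nM. Among the compounds with values here, its only measured companion is compound 2, `COc1cc2c(/C=C3/C(=O)Nc4cccc(Cl)c43)c(Cl)n(Cc3cc(OC)c(OC)c(OC)c3)c2cc1C`, which in this assay gives 2880 nM. Of these two numbers compound 1 has the lower one, but the gap is small: a 1.3-fold higher number from compound 1 to compound 2 (0.10 log units; within the scatter). So no order between the two can be claimed.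

Compound 3, `COc1ccc2c(c1)/C(=C\c1c(Cl)n(Cc3cc(OC)c(OC)c(OC)c3)c3cc(C)c(OC)cc13)C(=O)N2`, has not yet been measured. It differs from compound 1 in one place: methoxy in place of chloro on an aromatic carbon. Within the data shown here, the one measured step, from compound 1 to compound 2, exchanges one chloro-bearing group for another and does not bring in a methoxy at all, so it bears on this change only loosely; what it does show is that a change on this part of the molecule left the number within the scatter. Because a 1.3-fold higher number from compound 1 to compound 2 (0.10 log units; within the scatter) was so small, the step of a 1.1-fold higher number from compound 1 to compound 3 (0.04 log units; within the scatter) is expected to stay within the scatter as well, in no particular direction. Compound 3 is therefore estimated to give 2500 nM in this assay, within 1000 nM to 6500 nM.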

Compound 3, concentration for 50% growth inhibition: 14800 nM
Compound 3: the middle estimate sits 5.9-fold (0.77 log units) below what was measured, outside the stated range (above it).
By their numbers in this assay, from the lowest: compounds 1 and 2 (each within the scatter of the next); then compound 3.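

In this assay the change of methoxy in place of chloro on this aromatic carbon is a real one (a 6.5-fold higher number from compound 1 to compound 3 (0.81 log units; beyond the scatter)), modest in size but beyond the scatter, and compound 3 is the weaker inhibitor of growth. The earlier step (a 1.3-fold higher number from compound 1 to compound 2 (0.10 log units; within the scatter)) kept a chloro on the same six-membered ring and could not show this, so only now is it clear that the number responds to which group stands at this position of the core of compound 1. The compounds shown offer no measurement that explains why methoxy raises the number here.

From the compounds shown here alone, it remains open whether the rise belongs to methoxy in particular or would follow any replacement of chloro at this position, since only these two groups appear there, and a fluoro, a methyl, an ethoxy, an amine or a carboxylic acid would help to separate those readings. Going by these compounds, it is also open whether methoxy would give a similar step at the other ring carbon that carries chloro in compound 2.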